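Removing the cyclohexyl from the ring nitrogen of compound 1

The compounds below may be only part of what the source reports. "The series", "measured", "known", "first", "only" and "open" are said of these compounds alone.

Compound 1 `CCC(=O)Nc1ccc(-c2nc3cc(C(F)(F)F)ccc3n2C2CCCCC2)cc1` is a small set of related compounds tested for harm to cells in an ADME assay on MDBK cells (Bos taurus) for cytotoxicity, read by MTT assay, with a stated time of 96 h (on this read-out higher numbers stand for lower toxicity in this test and lower numbers for higher toxicity in this test), where compound 1 gives 18000 nM. This is the higher of the two numbers available, and the nearest is compound 2 `Oc1ccc(-c2nc3cc(Cl)c(Cl)cc3[nH]2)cc1`, which in this assay gives 11000 nM; the gap between the two lies within the scatter of repeated tests, so no order can be read from it. Compound 3 `COc1ccc(-c2nc3cc([N+](=O)[O-])ccc3[nH]2)c(OC)c1OC` reaches only a limit of the assay, > 100000 nM, not a number. Compound 4 `CCC(=O)Nc1ccc(-c2nc3cc(C(F)(F)F)ccc3[nH]2)cc1`, not yet measured, differs from compound 1 in one place: hydrogen in place of cyclohexyl on an aromatic nitrogen. Within the data shown here, no measured pair of compounds shows this change, so its effect must be judged from the compounds at hand. Since compounds 2 and 3, which both carry hydrogen on that aromatic nitrogen, give numbers no lower than compound 1, the step is expected to be small or to lean toward a higher number, roughly a 1.4-fold higher number from compound 1 to compound 4 (0.14 log units; within the scatter). Compound 4 is therefore estimated to give about 25000 nM, with a likely range from 8000 nM to 90000 nM.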

Compound 4, half-maximal cytotoxic concentration: > 100000 nM
Compound 4: no number, only a limit; the forecaster's own chance of this, stated with the estimate: 15%; at least 4.0-fold (0.60 log units) between middle value and limit.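

In this assay, among these compounds, hydrogen in place of cyclohexyl on the aromatic nitrogen gives an at least 5.5-fold higher number from compound 1 to compound 4 (0.74 log units; beyond the scatter), which is the first step read directly at this position. It shows that this single change can move the number beyond the usual scatter, something compounds 2 and 3 could not show, as each differs from compound 1 in more than one place. Compound 4 gives > 100000 nM, which is a limit of the assay and not a number, so the step has a known minimum but no known full size: the limit of > 100000 nM in this assay, at which 2 of the 4 values shown sit.

Only cyclohexyl and hydrogen are shown on this nitrogen. From the compounds shown here alone, whether a methyl group, a longer carbon chain or a chain ending in an amine would give a number nearer compound 1 or nearer compound 4 remains open.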